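Working notes: from compound 3 to compound 4

This account rests on a few compounds, and the source may have more. Where it says the series, first, only, none or still open, it means among the compounds named here.

Three members of the series have numbers in an ADME assay on Caco-2 cells (Homo sapiens) for permeability, in the apical to basolateral direction; on this read-out higher numbers stand for higher permeability and lower numbers for lower permeability. Compound 1 `Cn1cncc1CN1CC(N(CC2CCN(C(=O)c3ccco3)CC2)S(=O)(=O)c2ccccn2)Cc2cc(C#N)ccc21` gives 0.5 10^-6 cm/s. Compound 2 `CC(C)OC(=O)N1CCC(CN(C2Cc3cc(C#N)ccc3N(Cc3cncn3C)C2)S(=O)(=O)c2ccccn2)CC1` gives 1 10^-6 cm/s. Compound 3 `CCNC(=O)N1CCC(CN(C2Cc3cc(C#N)ccc3N(Cc3cncn3C)C2)S(=O)(=O)c2ccccn2)CC1` gives 0.6 10^-6 cm/s. Compound 3 sits within the scatter of both neighbours: the step of a 1.2-fold higher number from compound 1 to compound 3 (0.08 log units; within the scatter) and the step of a 1.7-fold lower number from compound 2 to compound 3 (0.22 log units; within the scatter) are each too small to count, as is the step of a 2.0-fold higher number from compound 1 to compound 2 (0.30 log units; within the scatter). All three measured steps exchange the group on the same carbonyl carbon, and none of them moved the number beyond the scatter.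

Compound 4 `Cn1cncc1CN1CC(N(CC2CCN(C(=O)c3ccccc3)CC2)S(=O)(=O)c2ccccn2)Cc2cc(C#N)ccc21` continues this pattern of exchange at that carbonyl carbon: phenyl in place of ethylamino on a carbonyl carbon. Within the data shown here, the nearest precedent is the step of a 1.2-fold higher number from compound 1 to compound 3 (0.08 log units; within the scatter), in which an aromatic ring on that carbonyl carbon gave way to ethylamino without a change beyond the scatter. On that basis the step of no change at the digits printed from compound 3 to compound 4 (within the scatter) is expected to be small, in no clear direction, and the value of compound 4 in this assay is estimated at 0.6 10^-6 cm/s, with a range from 0.25 10^-6 cm/s to 1.5 10^-6 cm/s.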

Compound 4, apparent permeability: 0.5 10^-6 cm/s
Beside the measured number, compound 4's estimate is 1.2-fold (0.08 log units) above it; the range from low to high includes it.
By their numbers in this assay, from the lowest: compounds 1, 4, 3 and 2 (each within the scatter of the next).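

Exchanging ethylamino for phenyl on this carbonyl carbon removes a hydrogen-bond donor and adds a six-membered aromatic ring of carbon only, yet in this assay the step stays within the scatter (a 1.2-fold lower number from compound 3 to compound 4 (0.08 log units; within the scatter)). The phenyl group also shows no step beyond the scatter against the heteroaromatic furan-2-yl (no change at the digits printed from compound 1 to compound 4 (within the scatter)) or against isopropoxy (a 2.0-fold lower number from compound 2 to compound 4 (0.30 log units; within the scatter)). Across compounds 1, 2, 3 and 4, the four groups on this carbonyl carbon, with or without a ring or a donor, give no step beyond the scatter, and no compound among them goes against this.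

No measurement at hand accounts for how closely these numbers agree. Still open, on these data alone, is whether a primary amine or a carboxylic acid on a longer chain at this carbonyl carbon would give a step beyond the scatter.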